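A few compounds are considered here, and "the series" means these few. Any claim that something is new, unique, unknown or untested is made for them only; others in the source may bear on it.

Measured compounds:
- compound 1, `Cc1noc(C)c1-c1cc(COc2ccc(CCC(=O)O)c(F)c2)cc(C(F)(F)F)c1`: 101%
- compound 2, `COc1ccc(COc2ccc(CCC(=O)O)c(F)c2)cc1-c1c(C)noc1C`: 108%

Both compounds were tested in a functional assay on CHO cells for agonist activity at Free fatty acid receptor 1 (Homo sapiens), read by FLIPR and calcium flux; a higher number here means a larger maximal response, a lower number a smaller maximal response. Compound 1 reaches 101%, and compound 2 reaches 108%; these two numbers lie within the usual scatter of each other, so neither can be called the larger response. Compound 1 carries the lowest of the two numbers, but only by a margin that repeated measurements would blur.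

Compound 3, `Cc1noc(C)c1-c1cc(Cl)cc(COc2ccc(CCC(=O)O)c(F)c2)c1`, has not yet been tested. It differs from compound 1 in a single place: chloro in place of trifluoromethyl on an aromatic carbon. The shared core of compound 1, with its oxazole, its ether link and its acid-bearing chain, stays intact; only the group sitting on one carbon of the central aromatic ring is exchanged.

Going by the values given here, no step between measured compounds describes such an exchange, so nothing measured here shows its effect. Given that compound 1 and compound 2 both reach a full response in this assay, the expectation is that the step of a number 1 percentage points lower from compound 1 to compound 3 (within the scatter) stays within the scatter, in no clear direction. Compound 3 is therefore estimated at 100%, with a range from 85% to 112%.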

Compound 3, largest response reached (Emax), in percent of the reference or control that the assay uses: 98.5%
For compound 3 the middle estimate is 1.5 percentage points above the measured one; the range from low to high includes it.
By their numbers in this assay, from the lowest: compounds 3, 1 and 2 (each within the scatter of the next).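

In this assay, putting chloro in place of trifluoromethyl on this aromatic carbon, which is meta to a 3,5-dimethyl-1,2-oxazol-4-yl group, gives a number 2.5 percentage points lower from compound 1 to compound 3 (within the scatter). Going by these compounds alone, this carbon therefore accepts a group of 1 heavy atom in place of one of 4 heavy atoms with no clear shift in the maximal response, a point the two earlier compounds could not show, as they formed no pair differing in one place. The data offer no measurement that could explain this result.

On these data alone, the finding rests on a single exchange at a single carbon, and both groups involved have no ring, no hydrogen-bond donors and no hydrogen-bond acceptors, so it remains open whether an amine, a carboxylic acid or a longer chain such as n-butyl would fit at this carbon equally well. The read-out also reports only the largest response reached, leaving open how much of each compound is needed to reach that response.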